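The compounds below may be only part of what the source reports. "The series", "measured", "known", "first", "only" and "open" are said of these compounds alone.

Four compounds share one core, and all four are tested in the same way. Compound 1, `COc1ccc(S(=O)(=O)Oc2ccccc2/C=C(\C#N)C(=O)Nc2nnc(Cc3cccc4ccccc34)s2)cc1`, and compound 3, `COc1ccc(S(=O)(=O)Oc2ccccc2/C=C(\C#N)C(=O)Nc2nnc(Cc3ccc(F)cc3)s2)cc1`, carry a methoxy group; compound 2, `N#C/C(=C\c1ccccc1OS(=O)(=O)c1ccc([N+](=O)[O-])cc1)C(=O)Nc1nnc(Cc2cccc3ccccc23)s1`, and compound 4, `N#C/C(=C\c1ccccc1OS(=O)(=O)c1ccc([N+](=O)[O-])cc1)C(=O)Nc1nnc(Cc2ccc(F)cc2)s1`, carry a nitro group in its place.

In a functional assay on RS4-11 cells (Homo sapiens) for inhibition, read by CCK-8 assay, with a stated time of 48 h, tested at 20 uM (a lower number here means less inhibition of growth, a higher number more inhibition of growth at the concentration tested), compound 1 gives 78%. Compound 2 gives 58% in this assay. Compound 3 gives 76% in this assay. Compound 4 has not yet been measured.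

Two changes connect these structures. The first is nitro in place of methoxy on an aromatic carbon. This change lowered the read-out: a number 20 percentage points lower from compound 1 to compound 2 (beyond the scatter). The second is 4-fluorophenyl in place of naphthalen-1-yl on a saturated chain carbon bound to an aromatic carbon. That change did little: a number 2 percentage points lower from compound 1 to compound 3 (within the scatter).

Compound 4 differs from compound 3 by nitro in place of methoxy on an aromatic carbon. Among the compounds with values here, this is the same change as the one from compound 1 to compound 2, made on the core of compound 3 instead of the core of compound 1. How those two cores differ is given by 4-fluorophenyl in place of naphthalen-1-yl on a saturated chain carbon bound to an aromatic carbon. Because the step of a number 2 percentage points lower from compound 1 to compound 3 (within the scatter) was small, the two cores look to behave alike, and the expectation is that the nitro change will cost about as much on the core of compound 3 as it did before. The expected step is a number 20 percentage points lower from compound 3 to compound 4 (beyond the scatter). For compound 4 the estimated result in this assay is 56%, expected to lie between 42% and 68%.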

Compound 4, percent growth inhibition at one concentration: 55%
Estimate against measurement, compound 4: 1 percentage points above, and the stated range covers the measured number.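

Putting nitro in place of methoxy on the core of compound 3 gives a number 21 percentage points lower from compound 3 to compound 4 (beyond the scatter) in this assay, and the same change on the core of compound 1 cost about as much, so in this pair of cores the change carried over with its size intact: the same change on two cores in this assay, a number 20 percentage points lower (beyond the scatter) from compound 1 to compound 2 and a number 21 percentage points lower (beyond the scatter) from compound 3 to compound 4, 1 percentage points apart, within the scatter of two such steps. The second change, 4-fluorophenyl in place of naphthalen-1-yl, gives a number 3 percentage points lower from compound 2 to compound 4 (within the scatter), and it stays small whether the compounds carry methoxy or nitro: the same change on two cores in this assay, a number 2 percentage points lower (within the scatter) from compound 1 to compound 3 and a number 3 percentage points lower (within the scatter) from compound 2 to compound 4, 1 percentage points apart, within the scatter of two such steps. Within the data shown here, this shows that the two changes behaved as independent of each other across these four compounds, but it rests on only two cores and one cell assay read at a single concentration, so it neither shows that the nitro change would cost the same on any other core nor explains why it lowers growth inhibition.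

The compounds shown leave open how other groups would behave in the place held by methoxy and nitro, such as an amine, a carboxylic acid or a chlorine atom. They also leave open whether the core tolerates something other than naphthalen-1-yl and 4-fluorophenyl on the saturated chain carbon, such as a plain cyclohexyl group or a longer chain.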